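The source may report more compounds than this note shows. Statements on the series, on what has been measured and on what is new or still open speak of the compounds shown alone.

In a functional assay on isolated protein for agonist activity at Glucose-dependent insulinotropic receptor (Rattus norvegicus), read by HTRF and cAMP accumulation (a higher number here means a larger maximal response, a lower number a smaller maximal response), compound 1 `CC(C)(C)OC(=O)N1CCC(O[C@H]2CC[C@H](Oc3ccc(S(C)(=O)=O)cc3)CC2)CC1` gives 120%, compound 2 `CC(C)OC(=O)N1CCC(O[C@H]2CC[C@H](Oc3ccc(S(C)(=O)=O)nc3)CC2)CC1` gives 125% and compound 3 `CC(C)OC(=O)N1CCC(O[C@H]2CC[C@H](Oc3cnc(S(C)(=O)=O)cn3)CC2)CC1` gives 120%. Among the compounds with values here, the one single-point step measured so far, a number 5 percentage points lower from compound 2 to compound 3 (within the scatter), changes the aryl group only. Compound 3 is thus level with compound 1 at the digits shown, and lies a small distance from compound 2 that stays within the scatter.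

Compound 4 `CS(=O)(=O)c1cnc(O[C@H]2CC[C@H](OC3CCN(CC4(C(F)(F)F)CC4)CC3)CC2)cn1` differs from compound 3 in (1-(trifluoromethyl)cyclopropyl)methyl in place of isopropoxycarbonyl on an amine nitrogen in a ring. Within the data shown here, no measured step touches the amine nitrogen in the ring, so none bears directly on this change; the measured variation across compounds 1, 2 and 3 is small. Compound 4 is therefore expected to give 115% in this assay, between 90% and 135%, a step of a number 5 percentage points lower from compound 3 to compound 4 (within the scatter) with no direction beyond the scatter.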

Compound 4, largest response reached (Emax), in percent of the reference or control that the assay uses: 124%
For compound 4 the middle estimate is 9 percentage points below the measured one; the measured number falls inside the stated range.
By their numbers in this assay, from the lowest: compounds 1, 3, 4 and 2 (each within the scatter of the next).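

In this assay, the amine nitrogen in the ring accepts (1-(trifluoromethyl)cyclopropyl)methyl in place of isopropoxycarbonyl with a number 4 percentage points higher from compound 3 to compound 4 (within the scatter). The entering group has no carbonyl and no hydrogen-bond acceptors, so in this pair neither is needed on that nitrogen for a maximal response of this size. Nothing available explains why the response holds across this exchange.

On these data alone, it remains open whether a simple benzyl group, an acetyl group or a chain ending in a carboxylic acid would be accepted on this nitrogen. Also open, as far as these compounds go, is whether the exchange behaves alike with the 6-(methylsulfonyl)pyridin-3-yl group of compound 2.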